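The source may report more compounds than this note shows. Statements on the series, on what has been measured and on what is new or still open speak of the compounds shown alone.

Measured in an ADME assay on BaF3 cells (Mus musculus) for antiproliferative activity, read by CCK-8 assay, with a stated time of 72 h; on this read-out lower numbers stand for stronger inhibition of growth and higher numbers for weaker inhibition of growth:
- compound 1 `O=C(CCSc1ccc2c(/C=C/c3ccccn3)n[nH]c2c1)Nc1cccc(F)c1`: 6590 nM
- compound 2 `O=C(CCSc1ccc2c(/C=C/c3ccccn3)n[nH]c2c1)Nc1cccc(Cl)c1`: 9350 nM
- compound 3 `COc1cccc(NC(=O)CCSc2ccc3c(/C=C/c4ccccn4)n[nH]c3c2)c1`: 3840 nM

Compound 3 sits at the low end of these numbers, though not clearly alone there: a 1.7-fold lower number from compound 1 to compound 3 (0.23 log units; within the scatter) stays within the scatter, while a 2.4-fold lower number from compound 2 to compound 3 (0.39 log units; beyond the scatter) goes beyond it.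

Compound 4 `CN(C)c1cccc(NC(=O)CCSc2ccc3c(/C=C/c4ccccn4)n[nH]c3c2)c1` is not yet measured. It keeps everything in compound 3 except one group: dimethylamino in place of methoxy on an aromatic carbon. In words, this is dimethylamino in place of methoxy on an aromatic carbon, meta to a large group.

Among the measured compounds shown here, the steps that bear on this are the swaps among the other groups at this same place. One more of them, a 1.4-fold higher number from compound 1 to compound 2 (0.15 log units; within the scatter), also stays within the scatter, and the largest, a 2.4-fold lower number from compound 2 to compound 3 (0.39 log units; beyond the scatter), is only modest. For the measured compounds named here, no measured compound carries dimethylamino, so this evidence is indirect. No step beyond the scatter is therefore expected in this assay.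

The estimated step is a 1.1-fold lower number from compound 3 to compound 4 (0.04 log units; within the scatter).

For compound 4 the expected value is 3500 nM, with an estimated range of 1500 nM to 8000 nM.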

Compound 4, concentration for 50% growth inhibition: > 10000 nM
Compound 4: only a limit was reported; the forecaster's own chance of this, stated with the estimate: 3%; middle value at least 2.8-fold (0.45 log units) away from the limit.
By their numbers in this assay, from the lowest: compounds 3, 1 and 2 (each within the scatter of the next, the first and the last beyond it). At a limit, above all of these: compound 4.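

At this place on the aromatic ring, dimethylamino in place of methoxy gives an at least 2.6-fold higher number from compound 3 to compound 4 (0.41 log units; beyond the scatter) in this assay, so the earlier swaps here did not show how far the number can climb with a single group changed. Set against the other two groups, the same change gives an at least 1.0-fold higher number from compound 2 to compound 4 (0.02 log units; that floor lies within the scatter) and an at least 1.5-fold higher number from compound 1 to compound 4 (0.18 log units; that floor lies within the scatter), floors that leave compound 4 unseparated from compound 1 and compound 2 in this assay. All three steps are floors and not full sizes, as compound 4 gave only a limit: the limit of > 10000 nM in this assay, at which 1 of the 4 values shown sits.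

Going by these compounds, how far compound 4 really lies past that limit remains open. A plain amine or a morpholine at this same place could show whether the loss belongs to dimethylamino alone or extends to other nitrogen groups.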